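The compounds below may be only part of what the source reports. "The series", "measured", "known", "first", "only" and "open" are said of these compounds alone.

Measured compounds:
compound 1 `COc1ccc(/C=N/NC(=O)Nc2ccc(Oc3ccnc4cc(OCCCN5CCCCC5)c(OC)cc34)c(F)c2)cc1` — in a functional assay on MKN-45 cells (Homo sapiens) for cytotoxicity, read by MTT assay, with a stated time of 72 h (a higher number here means a weaker inhibitor, a lower number a stronger inhibitor), compound 1 gives 660 nM.
compound 2 `COc1cc2c(Oc3ccc(NC(=O)N/N=C/c4ccc(F)cc4Cl)cc3F)ccnc2cc1OCCCN1CCCCC1` — in this assay compound 2 gives 270 nM.
compound 3 `COc1cc2c(Oc3ccc(NC(=O)N/N=C/c4ccc(Cl)cc4Cl)cc3F)ccnc2cc1OCCCN1CCCCC1` — in this assay compound 3 gives 460 nM.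

Compound 3 holds the second highest of the three numbers; its nearest neighbour is compound 1 (a 1.4-fold lower number from compound 1 to compound 3 (0.16 log units; within the scatter)), its furthest compound 2 (a 1.7-fold higher number from compound 2 to compound 3 (0.23 log units; within the scatter)), both within the scatter. The next change is pyridin-4-yl in place of 2,4-dichlorophenyl on a carbon with a double bond to nitrogen, giving compound 4 `COc1cc2c(Oc3ccc(NC(=O)N/N=C/c4ccncc4)cc3F)ccnc2cc1OCCCN1CCCCC1`. For the measured compounds named here, the steps that bear on it are the other swaps of the aryl group on the same carbon: a 2.4-fold lower number from compound 1 to compound 2 (0.39 log units; beyond the scatter) and a 1.4-fold lower number from compound 1 to compound 3 (0.16 log units; within the scatter), one modest and one within the scatter. Going by the values given here, no measured compound carries a pyridinyl group, so the expected step of a 1.3-fold higher number from compound 3 to compound 4 (0.12 log units; within the scatter) is at most modest, with no clear direction. Compound 4 is therefore estimated at 600 nM, with a range from 250 nM to 1500 nM.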

Compound 4, half-maximal inhibitory concentration: 980 nM
For compound 4 the middle estimate is 1.6-fold (0.21 log units) below the measured one, within the range that was stated.
By their numbers in this assay, from the lowest: compounds 2, 3, 1 and 4 (each within the scatter of the next, the first and the last beyond it).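

For the compounds shown here, on a carbon with a double bond to nitrogen, pyridin-4-yl is the first aryl swap that separates from the halogen-bearing rings on both counts: a 2.1-fold higher number from compound 3 to compound 4 (0.33 log units; beyond the scatter) and a 3.6-fold higher number from compound 2 to compound 4 (0.56 log units; beyond the scatter) are both modest but beyond the scatter. Against 4-methoxyphenyl there is no such separation, as a 1.5-fold higher number from compound 1 to compound 4 (0.17 log units; within the scatter) stays within it, so the gain over pyridin-4-yl is tied to the two halogen-bearing rings only. Nothing measured here accounts for these steps.
Still open, going by these compounds, is whether pyridin-3-yl, or a phenyl carrying a dimethylamino group or a carboxylic acid, would sit with pyridin-4-yl or with the halogen-bearing rings.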